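Compound 2 and a changed side chain

The source may hold more compounds than are shown below. What is called first, only, known or untested is meant among the compounds shown, and "the series" means these compounds.

In a functional assay (plasma) with Oryctolagus cuniculus as the target (a higher number here means a weaker inhibitor, a lower number a stronger inhibitor), compound 1 (`Cc1nc2cnccc2n1C1CCN(C(=O)CC(c2ccccc2)c2ccccc2)CC1`) gives 100 nM while compound 2 (`Cc1nc2cnccc2n1CC1CCN(C(=O)CC(C)(C)c2ccccc2)CC1`) gives 6.7 nM which is the lower of the two numbers, beyond the scatter. Compound 3 (`COc1ccccc1CCC(=O)N1CCC(Cn2c(C)nc3cnccc32)CC1`) differs from compound 2 in one place (2-methoxybenzyl in place of 1-methyl-1-phenylethyl on a saturated chain carbon bound to a carbonyl carbon): 2-methoxybenzyl in place of 1-methyl-1-phenylethyl on a saturated chain carbon bound to a carbonyl carbon. Within the data shown here, no measured step shows this change, so the estimate is uncertain. A moderate rise in the number is expected, pointing to a weaker inhibitor, and the expected step is a 4.5-fold higher number from compound 2 to compound 3 (0.65 log units; beyond the scatter) beyond the scatter. Compound 3 is estimated at 30 nM (8 nM to 120 nM).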

Compound 3, half-maximal inhibitory concentration: 15 nM
For compound 3 the middle estimate is 2.0-fold (0.30 log units) above the measured one, within the range that was stated.
By their numbers in this assay, from the lowest: compound 2; then compound 3; then compound 1.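

In this assay, 2-methoxybenzyl in place of 1-methyl-1-phenylethyl on a saturated chain carbon bound to a carbonyl carbon gives a 2.2-fold higher number from compound 2 to compound 3 (0.35 log units; beyond the scatter), the first single-place change seen at this position. The position therefore accepts a group carrying a hydrogen-bond acceptor, at the cost of only a modest step. Nothing available explains this step.

The step does not separate the loss of the gem-dimethyl carbon from the arrival of the methoxy. Going by these compounds, how an amine or a carboxylic acid on the same chain carbon would read in this assay also remains open.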